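This account rests on a few compounds, and the source may have more. Where it says the series, first, only, none or still open, it means among the compounds named here.

Measured in a functional assay on A549 cells (Homo sapiens) for antiproliferative activity, read by MTT assay, with a stated time of 48 h; on this read-out higher numbers stand for weaker inhibition and lower numbers for stronger inhibition:
compound 1 `Cc1ccc(-c2cc(NC(=O)/C=C/c3ccc(Cl)cc3)n[nH]2)cc1` gives 1490 nM
compound 2 `O=C(/C=C/c1ccc(Br)cc1)Nc1cc(-c2ccc(Br)cc2)[nH]n1` gives 1360 nM
compound 3 `Cc1ccc(-c2cc(NC(=O)/C=C/c3ccc(F)cc3)n[nH]2)cc1` gives 1250 nM

The three values lie within the usual scatter of one another, so compound 3 at 1250 nM cannot be separated from compound 1 or compound 2 . The next compound, compound 4 `Cc1ccc(-c2cc(NC(=O)/C=C/c3ccc(Br)cc3)n[nH]2)cc1`, is yet to be measured. It differs from compound 3 by bromo in place of fluoro on an aromatic carbon, para to a large group (bromo in place of fluoro on an aromatic carbon). Within the data shown here, one measured step bears directly on this change. Fluoro in place of chloro at that same place gave a 1.2-fold lower number from compound 1 to compound 3 (0.08 log units; within the scatter), which is within the scatter. Compound 2 also holds a 4-bromophenyl group and gives 1360 nM, again level with the others. No step beyond the scatter is therefore expected in this assay. The estimated change is a 1.1-fold higher number from compound 3 to compound 4 (0.03 log units; within the scatter). For compound 4 the expected value is 1350 nM, with an estimated range of 850 nM to 2100 nM.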

Compound 4, half-maximal inhibitory concentration: 1590 nM
The estimate for compound 4 lay 1.2-fold (0.07 log units) below the measured number, and the stated range covers the measured number.
By their numbers in this assay, from the lowest: compounds 3, 2, 1 and 4 (each within the scatter of the next).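

Across the three halogens at this place, on an aromatic carbon para to a large group, this assay shows no separation: bromo in place of fluoro gives a 1.3-fold higher number from compound 3 to compound 4 (0.10 log units; within the scatter), and bromo in place of chloro gives a 1.1-fold higher number from compound 1 to compound 4 (0.03 log units; within the scatter). Methyl in place of bromo at a second place on an aromatic carbon gives a 1.2-fold higher number from compound 2 to compound 4 (0.07 log units; within the scatter), so neither place has yet produced a step beyond the scatter among these four compounds. No measurement shown bears on why these values stay level.

Going by these compounds, whether a group other than a halogen at the first place, such as an amine, a methoxy group or a carboxylic acid, would move the number beyond the scatter remains open. On these data alone, whether the level values also hold outside this assay remains open too.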